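The source may report more compounds than this note shows. Statements on the series, on what has been measured and on what is new or still open speak of the compounds shown alone.

Among the measured compounds shown here, in a functional assay on HCT-116 cells (Homo sapiens) for antiproliferative activity, read by MTT assay, with a stated time of 48 h (on this read-out higher numbers stand for weaker inhibition and lower numbers for stronger inhibition), compound 3 `CCCC(CCO)n1cnc2c(Cl)nc(F)nc21` gives 16500 nM, the only true number so far. Compound 1 `CC(CCO)n1cnc2c(Cl)ncnc21` gives > 50000 nM, which is a limit of the assay. Compound 2 `CCC(CCO)n1cnc2c(Cl)ncnc21` gives > 50000 nM, also a limit. Much of the picture therefore rests on (the limit of > 50000 nM in this assay, at which 2 of the 3 values shown sit).

Compound 4 `CCCC(CCO)n1cnc2c(Cl)ncnc21` differs from compound 3 by hydrogen in place of fluoro on an aromatic carbon between two ring nitrogen atoms. For the measured compounds named here, the only measured step, a step that the two limits leave unreadable from compound 1 to compound 2, lies on the saturated chain and gives no size to carry over. Going by the values given here, no measured step covers the change at the aromatic carbon. Compound 1 and compound 2 both carry hydrogen there, but they also differ from compound 3 in the chain, so they are only an indirect guide. Compound 2, with hydrogen at that carbon, reads > 50000 nM, a limit, and this points towards weaker inhibition in this assay.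

An estimated 1.8-fold higher number from compound 3 to compound 4 (0.26 log units; within the scatter) is expected, and a reading at the limit remains possible. For compound 4 the estimated value is 30000 nM, with an expected range of 12000 nM to 70000 nM.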

Compound 4, half-maximal inhibitory concentration: > 50000 nM
Compound 4: only a limit was reported; the forecaster's own chance of this, stated with the estimate: 40%; at least 1.6-fold (0.22 log units) between middle value and limit.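

The change at the aromatic carbon between two ring nitrogen atoms now has a direction and a minimum size: hydrogen in place of fluoro gives an at least 3.0-fold higher number from compound 3 to compound 4 (0.48 log units; beyond the scatter). Among the compounds shown, compound 3 is the only one with fluoro and the only one that gives a true number in this assay, so fluoro at this position is the one change seen to matter so far. The steps among compound 1, compound 2 and compound 4 cannot be read, and the effect of the chain stays hidden with hydrogen at this carbon: the limit of > 50000 nM in this assay, at which 3 of the 4 values shown sit.

From the compounds shown here alone, it remains open whether an amine or a methoxy group at this aromatic carbon would read like fluoro or like hydrogen. Going by these compounds, how a shorter or longer chain behaves alongside fluoro is also open.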